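A few compounds are considered here, and "the series" means these few. Any claim that something is new, unique, unknown or untested is made for them only; others in the source may bear on it.

Compound 1 `Nc1ccccc1NC(=O)c1ccc(CSC(=S)N2CCc3ccccc32)cc1` was tested in a functional assay on HeLa cells (Homo sapiens) for antiproliferative activity, read by CCK-8 assay, with a stated time of 72 h, tested at 2 uM (on this read-out lower numbers stand for a weaker effect and higher numbers for a stronger effect at the one concentration tested), and gives 38%, the lowest of the three numbers recorded. Its nearest neighbour is compound 2 `CC1CCCCN1C(=S)SCc1ccc(C(=O)Nc2ccccc2N)cc1`, which in this assay gives 45.5%, a difference of a number 7.5 percentage points higher from compound 1 to compound 2 (within the scatter). Compound 3 `CCN(Cc1ccncc1)C(=S)SCc1ccc(C(=O)Nc2ccccc2N)cc1` stands furthest away and in this assay gives 63.5%, so that a number 25.5 percentage points higher from compound 1 to compound 3 (beyond the scatter) and, between the two substituted partners, a number 18 percentage points higher from compound 2 to compound 3 (beyond the scatter).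

Compound 4 `COC(=O)c1ccc2c(c1)CCN2C(=S)SCc1ccc(C(=O)Nc2ccccc2N)cc1` has not yet been measured. Relative to compound 1 the change is methoxycarbonyl in place of hydrogen on an aromatic carbon, placed on the aromatic carbon of the six-membered ring within the fused system, meta to one fused position and para to the other. The measured steps all exchange the whole 2,3-dihydro-1H-indol-1-yl group on the thiocarbonyl carbon for a different amine; none of them keeps that group and decorates its aromatic ring. They therefore do not bear directly on the step from compound 1 to compound 4, and the expectation rests on the absence of any pointer toward a change beyond the scatter. Compound 4 is accordingly expected to give about 40% in this assay, within a range from 22% to 58%, which corresponds to an expected step of a number 2 percentage points higher from compound 1 to compound 4 (within the scatter).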

Compound 4, a percentage reported as inhibition, at one concentration (the size of the read-out at that concentration, not a potency): 45.3%
For compound 4 the middle estimate is 5.3 percentage points below the measured one, and the stated range covers the measured number.
By their numbers in this assay, from the lowest: compounds 1, 4 and 2 (each within the scatter of the next); then compound 3.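

In this assay, methoxycarbonyl in place of hydrogen on an aromatic carbon of the fused system gives a number 7.3 percentage points higher from compound 1 to compound 4 (within the scatter), so at this position, meta to one fused ring position and para to the other, the added group leaves the read-out within the usual scatter of compound 1. This is the first step shown that keeps the 2,3-dihydro-1H-indol-1-yl group and decorates its aromatic ring, whereas the earlier steps exchanged that whole group for a different amine, and it shows that this position accepts an ester of this size with no change beyond the scatter at the single concentration tested. Nothing in the data available speaks to why this step has the size it has.

The compounds shown leave open whether a carboxylic acid, an amine or a longer ester chain at the same aromatic carbon would also stay within the scatter of compound 1. They also leave open how methoxycarbonyl would read on the other aromatic carbons of that ring, and whether a reading at one concentration would hold up as a difference in potency.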